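This account rests on a few compounds, and the source may have more. Where it says the series, first, only, none or still open, it means among the compounds named here.

Compound 3 `CCOCCOc1cccc2ccc(N)nc12` shares its core with compound 1 `Nc1ccc2cccc(OC3CCC3)c2n1` and compound 2 `CC1CCCC(Oc2cccc3ccc(N)nc23)C1`, each carrying a different group on the oxygen on the aromatic ring. In an assay on cells with melanin-concentrating hormone receptor 1 (Homo sapiens) as the target, read by radioligand binding (on this read-out higher numbers stand for weaker inhibition and lower numbers for stronger inhibition), compound 3 gives > 2000 nM, which is a limit of the assay and not a number. Compound 1 likewise gives only a limit, > 2000 nM. Compound 2 gives 640 nM. The step that the two limits leave unreadable from compound 1 to compound 3 is unreadable, because the limit of > 2000 nM in this assay, at which 2 of the 3 values shown sit, caps both of its ends. Among the numbers shown, compound 3 therefore stands only as a limit, with no numerical position of its own.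

Compound 4 `CC#CCCOc1cccc2ccc(N)nc12` differs from compound 3 by prop-1-yn-1-yl in place of ethoxy on a saturated chain carbon, two bonds along the chain from an oxygen on an aromatic ring. No measured step involves a change of this kind; the only single-place step shown, from cyclobutyl to 2-ethoxyethyl, is unreadable, and compound 2 shows merely that a 3-methylcyclohexyl group on that oxygen reaches a measurable number. With pent-3-yn-1-yl in place of 2-ethoxyethyl, compound 4 is expected to stay near the limit, so the step that the limit leaves unreadable from compound 3 to compound 4 is expected to be small, without a clear direction. Compound 4 is accordingly estimated at 2500 nM in this assay, with a range from 600 nM to 10000 nM.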

Compound 4, half-maximal inhibitory concentration: > 2000 nM
Compound 4 gave a limit, no number (the forecaster's own chance of this, stated with the estimate: 55%); the middle value is on the limit's open side.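

Compound 4 gives > 2000 nM in this assay, which is a limit of the assay and not a number. The steps from compound 3 to compound 4 and from compound 1 to compound 4 therefore cannot be read, because both ends of each are capped: the limit of > 2000 nM in this assay, at which 3 of the 4 values shown sit.

The compounds shown leave open how far compound 1, compound 3 and compound 4 lie from one another.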